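Replacing dimethylamino with fluoro in a growth inhibitor

A few compounds are considered here, and "the series" means these few. Any claim that something is new, unique, unknown or untested is made for them only; others in the source may bear on it.

Among the compounds with values here, compound 1 `Cc1ccc2[nH]c(-c3ccc(-c4ccc(-c5ccc(N(C)C)cc5)cc4)cc3)nc2c1` has the lower of the two numbers so far. In a functional assay on PC-3 cells (Homo sapiens) for inhibition, read by sulforhodamine B assay (on this read-out higher numbers stand for weaker inhibition of growth and lower numbers for stronger inhibition of growth), compound 1 gives 8120 nM while compound 2 `CN(C)c1ccc(-c2ccc(-c3ccc(-c4nc5ccccc5[nH]4)cc3)cc2)cc1` gives 100000 nM and so shows the weaker inhibition of growth. Within the data shown here, the one measured step runs a 12-fold higher number from compound 1 to compound 2 (1.09 log units; beyond the scatter) and is large, well beyond the scatter, with hydrogen in place of methyl on an aromatic carbon. Compound 3 `Cc1ccc2[nH]c(-c3ccc(-c4ccc(-c5ccc(F)cc5)cc4)cc3)nc2c1` keeps that methyl and carries fluoro in place of dimethylamino on an aromatic carbon. Among the measured compounds shown here, no measured step alters that group, so the methyl step bears on this change only indirectly. It shows that one small change can move the number a long way in these compounds, but it gives no direction for this swap. For the measured compounds named here, with compound 1 at 8120 nM as the only anchor, no step clearly beyond the scatter can be predicted. The estimated change is a 1.2-fold higher number from compound 1 to compound 3 (0.09 log units; within the scatter) with wide uncertainty either way. In this assay compound 3 is expected to give 10000 nM and to fall in the estimated range from 2500 nM to 45000 nM in most repeats.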

Compound 3, concentration for 50% growth inhibition: 100000 nM
For compound 3 the middle estimate is 10-fold (1.00 log units) below the measured one, and the stated range ends below it.
By their numbers in this assay, from the lowest: compound 1; then compounds 2 and 3 (each within the scatter of the next).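

In this assay, the step of a 12-fold higher number from compound 1 to compound 3 (1.09 log units; beyond the scatter) shows that the group on the outer benzene ring matters as well, since fluoro in place of dimethylamino, with the methyl kept, gives much weaker inhibition of growth. Within the data shown here, earlier, the only measured change was the loss of the methyl, a 12-fold higher number from compound 1 to compound 2 (1.09 log units; beyond the scatter), so this result adds a second place in the molecule where a single change has a large effect, and it gives this swap the direction that the methyl step could not. Nothing available here bears on what lies behind the weaker inhibition with fluoro, so the result records an effect and not a cause.

These compounds cannot separate losing dimethylamino from gaining fluoro, as the step carries both at once and only this one replacement at this place is shown. Going by these compounds, whether a plain amino group, a methoxy group or a chlorine at the same place would stay close to compound 1 or fall away as fluoro does remains open, and so does whether a larger amine such as a morpholine would be tolerated there.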